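Trading a Ring Amine for a Plain Methyl

This account rests on a few compounds, and the source may have more. Where it says the series, first, only, none or still open, it means among the compounds named here.

Of the compounds shown here, three sharing one core have been tested in an assay on HEK293 cells for agonist activity at Toll-like receptor 8 (Homo sapiens), read by spectrophotometry; on this read-out lower numbers stand for an effect already at smaller amounts and higher numbers for an effect only at larger amounts of compound. Compound 3 `CCCCNc1nc(N)nc(C)c1CCCN1CCCC1` gives 110 nM; compound 1 `CCCCNc1nc(N)nc(C)c1CCCN1CCCCCC1` gives 178 nM; and compound 2 `CCCCNc1nc(N)nc(C)c1C` gives 3280 nM. Compound 3 thus has the lowest number of the three, though its distance from compound 1 is small: the step of a 1.6-fold lower number from compound 1 to compound 3 (0.21 log units; within the scatter) stays within the scatter, so the two cannot be ranked. The step of a 30-fold lower number from compound 2 to compound 3 (1.47 log units; beyond the scatter) is a different matter, a large gain from a compound carrying only a methyl to one carrying the longer amine-bearing chain.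

Compound 4 `CCCCNc1nc(N)nc(C)c1CCCC` is the next compound. Its difference from compound 3 is methyl in place of pyrrolidin-1-yl on a saturated chain carbon, three bonds along the chain from an aromatic carbon. The chain keeps its length but the ring amine at its end is gone, leaving a plain alkyl chain.

Among the compounds with values here, the step that bears most on this is the one from compound 2 to compound 3, where adding the amine-bearing chain brought the large improvement just described. Within the data shown here, compound 4 keeps part of that chain but loses the ring amine, and no measured pair separates the chain from the amine. A step back toward the number of compound 2 is therefore expected, though perhaps not all the way: the estimate for the step is a 14-fold higher number from compound 3 to compound 4 (1.13 log units; beyond the scatter). For compound 4 the expected value is 1500 nM, with a range from 400 nM to 6000 nM.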

Compound 4, half-maximal effective concentration: 780 nM
Estimate against measurement, compound 4: 1.9-fold (0.28 log units) above, and the stated range covers the measured number.
By their numbers in this assay, from the lowest: compounds 3 and 1 (each within the scatter of the next); then compound 4; then compound 2.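

The plain chain and the ring amine at its end can now be told apart in this assay. The propyl chain alone already counts for something, with a 4.2-fold lower number from compound 2 to compound 4 (0.62 log units; beyond the scatter) when propyl takes the place of hydrogen, and the pyrrolidin-1-yl group counts on top of it, as removing that ring gives a 7.1-fold higher number from compound 3 to compound 4 (0.85 log units; beyond the scatter) when methyl stands in its place. The azepan-1-yl group points the same way, with a 4.4-fold higher number from compound 1 to compound 4 (0.64 log units; beyond the scatter) for the same kind of exchange, so the large gain seen earlier from adding the full amine-bearing chain comes from both the chain and its ring amine rather than from one alone.

No measurement at hand explains why the ring amine lowers the number compared with the plain chain. From the compounds shown here alone, it also remains open whether a ring is needed at all or any amine will do at this place, a question that an open-chain dimethylamino group or a simple primary amine on the same chain would help to settle.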